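A few compounds are considered here, and "the series" means these few. Any claim that something is new, unique, unknown or untested is made for them only; others in the source may bear on it.

Measured compounds:
compound 1 `CN(C)CCn1c(=O)c(=Cc2ccc(F)c(F)c2)s/c1=C1\C(=O)Nc2cc(F)ccc21`, 25000 nM
compound 2 `CCN(CC)CCCn1c(=O)c(=Cc2ccc(F)c(F)c2)s/c1=C1\C(=O)Nc2cc(F)ccc21`, 2900 nM
compound 3 `CCN(CC)CCCn1c(=O)c(=Cc2ccccc2O)s/c1=C1\C(=O)Nc2ccc(Br)cc21`, 19900 nM

These three compounds share one core and were tested in a functional assay on MDA-MB-231 cells (Homo sapiens) for inhibition, read by MTT assay, with a stated time of 72 h; a lower number here means a stronger inhibitor, a higher number a weaker inhibitor. Compound 1 sits at the high end of the three numbers: compound 3, with 19900 nM, lies close to it, within the scatter, while compound 2, with 2900 nM, stands clearly apart. For the measured compounds named here, the single step among the measured compounds, an 8.6-fold lower number from compound 1 to compound 2 (0.94 log units; beyond the scatter), concerns only the chain on the aromatic nitrogen.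

Compound 4 `CN(C)CCn1c(=O)c(=Cc2ccc(C=O)c(C=O)c2)s/c1=C1\C(=O)Nc2cc(F)ccc21` has not yet been measured. It differs from compound 1 as follows: 3,4-diformylphenyl in place of 3,4-difluorophenyl on a double-bonded chain carbon bound to an aromatic carbon. Going by the values given here, none of the measured steps touches this part of the molecule; the one measured step, between compound 1 and compound 2, changes the amine on the chain and says nothing about the aryl group. There is therefore no basis in the data for expecting a step in either direction beyond the scatter for this change in this assay. Compound 4 is expected to give about 25000 nM, with a plausible range from 8000 nM to 80000 nM. The step this estimate implies, no change at the digits printed from compound 1 to compound 4 (within the scatter), is expected to fall within the usual scatter.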

Compound 4, half-maximal inhibitory concentration: 2420 nM
The estimate for compound 4 lay 10-fold (1.01 log units) above the measured number; the measured number lies below the stated range.
By their numbers in this assay, from the lowest: compounds 4 and 2 (each within the scatter of the next); then compounds 3 and 1 (each within the scatter of the next).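

In this assay, the aryl group on the double-bonded chain carbon proves to be a place where the number can move well beyond the scatter: 3,4-diformylphenyl in place of 3,4-difluorophenyl gives a 10-fold lower number from compound 1 to compound 4 (1.01 log units; beyond the scatter). With this result, both steps measured from compound 1 lead to a lower number, one through the amine chain on the aromatic nitrogen and the other through this aryl group, so the high number of compound 1 is not fixed by its aryl group alone. The entering group carries 2 hydrogen-bond acceptors and 2 double bonds outside aromatic rings, while the leaving group has neither, but no measurement here says which of these features, if either, accounts for the step.

As far as these compounds go, it remains open whether a phenyl group carrying nitrile or carboxylic acid groups at this place would give a similar number, or whether the formyl groups themselves are needed. From the compounds shown here alone, it is also open whether the diethylamino chain of compound 2 and the 3,4-diformylphenyl group of compound 4, placed on one molecule, would lower the number further.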